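Chloro in place of nitro in compound 1

The source may report more compounds than this note shows. Statements on the series, on what has been measured and on what is new or still open speak of the compounds shown alone.

Compound 1 `O=[N+]([O-])c1cccc(CSc2nnc(-c3ccc4c(c3)OCCO4)n2-c2ccccc2)c1`: 7590 nM
Compound 2 `O=[N+]([O-])c1ccc(CSc2nnc(-c3ccc4c(c3)OCCO4)n2-c2ccccc2)cc1`: 13800 nM

In a functional assay on SW 1116 cells (Homo sapiens) for antiproliferative activity, read by MTT assay, with a stated time of 24 h (a lower number here means a stronger inhibitor, a higher number a weaker inhibitor), compound 1 can be compared only with compound 2, and the two lie within the scatter of each other. Compound 3 `Clc1cccc(CSc2nnc(-c3ccc4c(c3)OCCO4)n2-c2ccccc2)c1` has chloro in place of nitro on an aromatic carbon, (chloro in place of nitro on an aromatic carbon), turning 3-nitrobenzyl into 3-chlorobenzyl. Going by the values given here, no measured step makes this exchange. The nearest evidence is a 1.8-fold higher number from compound 1 to compound 2 (0.26 log units; within the scatter), where 4-nitrophenyl replaces 3-nitrophenyl, so it suggests no direction, and no change beyond the scatter is expected in this assay. The expected change is a 1.1-fold higher number from compound 1 to compound 3 (0.02 log units; within the scatter). For compound 3 the estimate is 8000 nM, with an expected range of 2800 nM to 23000 nM.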

Compound 3, half-maximal inhibitory concentration: 10600 nM
Compound 3: the middle estimate sits 1.3-fold (0.12 log units) below what was measured, within the range that was stated.
By their numbers in this assay, from the lowest: compounds 1, 3 and 2 (each within the scatter of the next).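

In this assay, the 3-chlorobenzyl group of compound 3 shows that the nitro group can give way to chloro, with three heavy atoms and two hydrogen-bond acceptors leaving and one heavy atom and no acceptor entering, for only a 1.4-fold higher number from compound 1 to compound 3 (0.15 log units; within the scatter). Against the other nitro compound the picture is the same, with a 1.3-fold lower number from compound 2 to compound 3 (0.11 log units; within the scatter), so all three compounds stay close together. Nothing available explains this lack of separation. As far as these compounds go, whether an amine or a carboxylic acid on this aromatic carbon would stay equally close remains open. So does the reading for a longer chain in place of the benzyl carbon.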